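Thioether variation on the shared core: toward compound 4

The source may report more compounds than this note shows. Statements on the series, on what has been measured and on what is new or still open speak of the compounds shown alone.

Compound 1, `CCCSc1nc2nc(C)cc(N3CC[C@@H](C)[C@@H](N(C)c4ncnc5[nH]ccc45)C3)n2n1`, gives 67100 nM.
Compound 2, `Cc1cc(N2CC[C@@H](C)[C@@H](N(C)c3ncnc4[nH]ccc34)C2)n2nc(SCc3ccc(Br)cc3)nc2n1`, gives 55600 nM.
Compound 3, `Cc1cc(N2CC[C@@H](C)[C@@H](N(C)c3ncnc4[nH]ccc34)C2)n2nc(SCCCc3ccccc3)nc2n1`, gives only a limit, > 100000 nM.

In a toxicity assay on GES1 cells (Homo sapiens) for inhibition, read by MTT assay, with a stated time of 72 h (a higher number here means a weaker inhibitor, a lower number a stronger inhibitor), compound 1 and compound 2 both sit at weak inhibition. For compound 3 the read-out is a limit and not a number; it stands at the limit of > 100000 nM in this assay, at which 1 of the 3 values shown sits, so its place among the three is known only as a floor. The measured steps are small: a 1.2-fold lower number from compound 1 to compound 2 (0.08 log units; within the scatter), an at least 1.4-fold higher number from compound 1 to compound 3 (0.17 log units; that floor lies within the scatter) and an at least 1.7-fold higher number from compound 2 to compound 3 (0.25 log units; that floor lies within the scatter). None of them reaches beyond the scatter.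

Compound 4, `COc1ccc(CSc2nc3nc(C)cc(N4CC[C@@H](C)[C@@H](N(C)c5ncnc6[nH]ccc56)C4)n3n2)cc1`, has not been measured. The change from compound 3 is 4-methoxyphenyl in place of phenethyl on a saturated chain carbon bound to a sulfur. For the measured compounds named here, the step that bears on it most directly is the one from compound 2 to compound 3, where 4-bromophenyl on the saturated chain carbon bound to a sulfur left and phenethyl entered; compound 4 brings an aryl group back onto that carbon. Compound 2 gives 55600 nM in this assay, and compound 4 is therefore expected to land near that, with an expected step of an at least 1.5-fold lower number from compound 3 to compound 4 (0.18 log units; that floor lies within the scatter) whose size cannot be fixed firmly because compound 3 stands at the limit of > 100000 nM in this assay, at which 1 of the 3 values shown sits. Compound 4 is estimated at 65000 nM, with a range from 30000 nM to 150000 nM.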

Compound 4, half-maximal inhibitory concentration: > 100000 nM
Compound 4 gave a limit, no number (the forecaster's own chance of this, stated with the estimate: 30%); at least 1.5-fold (0.18 log units) between middle value and limit.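

In this assay compound 4 gives only a limit, > 100000 nM, so an aryl group returned to the saturated chain carbon bound to a sulfur does not by itself bring the read-out back to a measured number. Methoxy in place of bromo on an aromatic carbon gives an at least 1.7-fold higher number from compound 2 to compound 4 (0.25 log units; that floor lies within the scatter), and 4-methoxyphenyl in place of ethyl at the chain position gives an at least 1.4-fold higher number from compound 1 to compound 4 (0.17 log units; that floor lies within the scatter), so neither comparison sets compound 4 firmly apart from the two compounds with measured numbers. Compound 3 and compound 4, the (3-phenylpropyl)sulfanyl and (4-methoxybenzyl)sulfanyl members, both stand at the limit, and the step between them cannot be read: the limit of > 100000 nM in this assay, at which 2 of the 4 values shown sit.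

On these data alone, how far compound 3 and compound 4 actually lie past the limit stays open, as does whether the change from bromo to methoxy on the aromatic carbon has any real size. Also open, as far as these compounds go, is how a thioether chain ending in an amine or a carboxylic acid would read in this assay.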